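Indole carbohydrazide series: methylation of the amide-side indole nitrogen

The compounds below may be only part of what the source reports. "The series", "measured", "known", "first", "only" and "open" are said of these compounds alone.

Within the data shown here, the three measured members share a hydrazone-linked indole carbohydrazide core. Compound 1 `O=C(N/N=C\c1cn(Cc2ccc(Cl)cc2)c2ccc(Br)cc12)c1c[nH]c2ccccc12` gives 8700 nM in a functional assay on MIA PaCa-2 cells (Homo sapiens) for cytotoxicity; a higher number here means a weaker inhibitor, a lower number a stronger inhibitor. Compound 2 `O=C(N/N=C\c1cn(Cc2ccc(Cl)cc2)c2cc(F)ccc12)c1c[nH]c2ccccc12` gives 18000 nM in this assay. Compound 3 `COc1ccc(Cn2cc(/C=N\NC(=O)c3c[nH]c4ccccc34)c3ccccc32)cc1` gives 41600 nM in this assay. Compound 2 thus stands second highest of the three numbers: compound 1 sits lower and compound 3 sits higher, both gaps beyond the scatter. Compound 4 `Cn1cc(C(=O)N/N=C\c2cn(Cc3ccc(Cl)cc3)c3cc(F)ccc23)c2ccccc21` is not yet measured; it differs from compound 2 in one place: methyl in place of hydrogen on an aromatic nitrogen. Among the measured compounds shown here, with no comparable step among the measured compounds, only a small step is expected, if any, slightly toward a higher number: the expected step of a 1.4-fold higher number from compound 2 to compound 4 (0.14 log units; within the scatter) in this assay. Compound 4 is estimated at 25000 nM, within 9000 nM to 70000 nM.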

Compound 4, half-maximal inhibitory concentration: 50400 nM
Compound 4: the middle estimate sits 2.0-fold (0.30 log units) below what was measured, within the range that was stated.
By their numbers in this assay, from the lowest: compound 1; then compound 2; then compounds 3 and 4 (each within the scatter of the next).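

Methyl in place of hydrogen on the aromatic nitrogen gives a 2.8-fold higher number from compound 2 to compound 4 (0.45 log units; beyond the scatter) in this assay. Among these compounds, this is the first single-change step, and it shows that this position is sensitive to substitution, with the change weakening inhibition beyond the scatter. Nothing available explains the loss.

On these data alone, whether the loss follows from removing the hydrogen or from the size of the new group remains open, as an ethyl or a longer aminoalkyl chain on that nitrogen would be needed to separate the two. As far as these compounds go, whether the step carries over to the core of compound 1 is also open.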